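Moving the hydroxy group from compound 2 to compound 3

This account rests on a few compounds, and the source may have more. Where it says the series, first, only, none or still open, it means among the compounds named here.

In a functional assay on TK-10 cells (Homo sapiens) for inhibition, read by sulforhodamine B assay, with a stated time of 48 h (on this read-out higher numbers stand for weaker inhibition of growth and lower numbers for stronger inhibition of growth), compound 2 (`O=C(Cc1csc2nc(-c3ccc(Br)cc3)cn12)N/N=C/c1ccccc1O`) holds the lower of the two numbers at 8710 nM against compound 1 (`O=C(Cc1csc2nc(-c3ccc(Br)cc3)cn12)N/N=C/c1ccccc1`) at 41700 nM so far. Compound 3 (`O=C(Cc1csc2nc(-c3ccc(Br)cc3)cn12)N/N=C/c1ccc(O)cc1`) has 4-hydroxyphenyl in place of 2-hydroxyphenyl on a carbon with a double bond to nitrogen. Among the measured compounds shown here, the one measured step bearing on this is a 4.8-fold lower number from compound 1 to compound 2 (0.68 log units; beyond the scatter) for hydroxy in place of hydrogen on an aromatic carbon, modest but beyond the scatter. For the measured compounds named here, no measurement yet compares the two hydroxy placements, so only part of that step is expected to carry over. The expected change is a 1.6-fold higher number from compound 2 to compound 3 (0.21 log units; within the scatter) and thus small. Compound 3 is estimated at 14000 nM (range 5500 nM to 38000 nM).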

Compound 3, concentration for total growth inhibition: 33100 nM
Estimate against measurement, compound 3: 2.4-fold (0.37 log units) below; measured number inside the range.
By their numbers in this assay, from the lowest: compound 2; then compounds 3 and 1 (each within the scatter of the next).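

In this assay the gain from a hydroxy group proves to depend on where it sits: moving to 4-hydroxyphenyl gives a 3.8-fold higher number from compound 2 to compound 3 (0.58 log units; beyond the scatter) and so gives up the separation that compound 2 had shown. Hydroxy in place of hydrogen in this placement gives only a 1.3-fold lower number from compound 1 to compound 3 (0.10 log units; within the scatter) and so leaves compound 3 within the scatter of compound 1. Among these compounds, only the 2-hydroxyphenyl group stands apart. Nothing available explains the difference between the two placements.

The compounds shown leave open whether a methoxy group or an amine in place of that hydroxy would keep the lower number of compound 2.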